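The source may hold more compounds than are shown below. What is called first, only, known or untested is meant among the compounds shown, and "the series" means these compounds.

Working notes on the series. Of the compounds shown here, two have been measured in a functional assay on PC-3 cells (Homo sapiens) for cytotoxicity, read by MTT assay, with a stated time of 48 h; a lower number here means a stronger inhibitor, a higher number a weaker inhibitor. Compound 1 `COc1cc(-c2nnc3n2NC(c2ccco2)C(C(=O)c2ccc(Cl)cc2)S3)cc(OC)c1OC` gives 67800 nM in this assay. Compound 2 `COc1ccc(C(=O)C2Sc3nnc(-c4cc(OC)c(OC)c(OC)c4)n3NC2c2cccs2)cc1` gives 95900 nM in this assay, the higher of the two numbers; its nearest neighbour is compound 1, and the gap between the two lies within the scatter, so no order between them can be read. Within the data shown here, no pair that differs in a single place has been measured, so no step size is known from the data.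

Compound 3 `COc1cc(-c2nnc3n2NC(c2cccs2)C(C(=O)c2ccc(Cl)cc2)S3)cc(OC)c1OC` is the next member to be measured. It differs from compound 2 by chloro in place of methoxy on an aromatic carbon. Compound 1 carries the same chloro group and sits within the scatter of compound 2, so the step from compound 2 to compound 3 in this assay is expected to be small, estimated as a 1.3-fold lower number from compound 2 to compound 3 (0.11 log units; within the scatter), with no change beyond the scatter. Compound 3 is expected to give about 75000 nM in this assay, within a range of 30000 nM to 180000 nM.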

Compound 3, half-maximal inhibitory concentration: 32500 nM
Estimate against measurement, compound 3: 2.3-fold (0.36 log units) above, and the stated range covers the measured number.
By their numbers in this assay, from the lowest: compound 3; then compounds 1 and 2 (each within the scatter of the next).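

In this assay both changes now have a size, and each step lies beyond the scatter: chloro in place of methoxy on an aromatic carbon, para to a large group, gives the first (a 3.0-fold lower number from compound 2 to compound 3 (0.47 log units; beyond the scatter)), and thiophen-2-yl in place of furan-2-yl on a saturated ring carbon gives the second (a 2.1-fold lower number from compound 1 to compound 3 (0.32 log units; beyond the scatter)). Both steps are modest, and each rests on a single pair, so the number responds to a change at either place, with compound 3 lowest of the three. Nothing at hand bears on the cause of either step.

As far as these compounds go, whether the chloro step holds with furan-2-yl in place of thiophen-2-yl remains open, so the two steps cannot yet be called additive. Also open, from the compounds shown here alone, is how a fluoro, hydroxy or dimethylamino group would compare with chloro at the same place.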